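Adding a Methylpiperazine to the Amidine Aryl Ring

A few compounds are considered here, and "the series" means these few. Any claim that something is new, unique, unknown or untested is made for them only; others in the source may bear on it.

Compound 1 `COc1cc(Nc2nc(C(=N)Nc3ccc(N4CCN(C)CC4)cc3)cc3c(-c4ccccc4)n[nH]c23)cc(OC)c1OC`: 4300 nM
Compound 2 `COc1cc(Nc2nc(C(=N)Nc3ccccc3)cc3c(-c4ccccc4)n[nH]c23)cc(OC)c1OC`: 5800 nM
Compound 3 `COc1ccc(Cn2nc(-c3ccccc3)c3cc(C(=N)Nc4ccccc4)nc(NC4CCCCC4)c32)cc1`: 1100 nM

These three compounds were tested in a functional assay on PC-3 cells (Homo sapiens) for cytotoxicity, read by MTT assay, with a stated time of 72 h; on this read-out lower numbers stand for stronger inhibition and higher numbers for weaker inhibition. Compound 1 differs from compound 2 only by 4-methylpiperazin-1-yl in place of hydrogen on an aromatic carbon, and this gave a 1.3-fold lower number from compound 2 to compound 1 (0.13 log units; within the scatter). Compound 3 carries a different core; the difference between the core of compound 3 and that of compound 2 is not broken down here. Compound 3 shows the lowest number of the three, beyond the scatter against both compound 1 and compound 2.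

Compound 4 `COc1ccc(Cn2nc(-c3ccccc3)c3cc(C(=N)Nc4ccc(N5CCN(C)CC5)cc4)nc(NC4CCCCC4)c32)cc1` has not yet been measured in this assay. It differs from compound 3 by 4-methylpiperazin-1-yl in place of hydrogen on an aromatic carbon, the same change that leads from compound 2 to compound 1. Since that earlier step stayed within the scatter, a similarly small movement is expected from compound 3 to compound 4, namely a 1.2-fold lower number from compound 3 to compound 4 (0.09 log units; within the scatter). Compound 4 is therefore estimated at 900 nM, with a likely range from 400 nM to 2200 nM.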

Compound 4, half-maximal inhibitory concentration: 3540 nM
Compound 4: the middle estimate sits 3.9-fold (0.59 log units) below what was measured; measured number outside the range, above it.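

In this assay, 4-methylpiperazin-1-yl in place of hydrogen on an aromatic carbon gave a 3.2-fold higher number from compound 3 to compound 4 (0.51 log units; beyond the scatter), so the small step seen on the first core did not carry over to the second. The two steps differ clearly: the same change on two cores in this assay, a 1.3-fold lower number (0.13 log units; within the scatter) from compound 2 to compound 1 and a 3.2-fold higher number (0.51 log units; beyond the scatter) from compound 3 to compound 4, 4.3-fold (0.64 log units) apart, beyond the scatter of two such steps This shows that, in these two pairs, the result of the change depends on the core that carries it, but two pairs do not show which feature of the cores matters or how the change would behave on a further core.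

The compounds shown leave open whether morpholine or a piperazine without the methyl group, set in the same place, would split the two cores in the same way.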